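The compounds below may be only part of what the source reports. "The series", "measured", "known", "first", "only" and "open" are said of these compounds alone.

Measured so far:
Compound 1 `CCCCC/C=C/CCCCCCCCCC1(C(=O)OC)CO1` — 5 uM
Compound 2 `CCCCCCC1(C(=O)OC)CO1` — 20 uM

In a functional assay for inhibition, with Rattus norvegicus as the target (a higher number here means that more compound is needed for the effect, a lower number that less compound is needed), compound 1 gives 5 uM, the lower of the two numbers at hand. Compound 2, in this assay, gives 20 uM, a higher number, and the gap between the two lies beyond the usual scatter. The two compounds differ in more than one place, so their values are only reported side by side here.

Compound 3 `CCCCCCCCCCC1(C(=O)OC)CO1` has not yet been measured in this assay. It differs from compound 1 in one place: methyl in place of hept-1-en-1-yl on a saturated chain carbon, nine bonds along the chain from a saturated ring carbon. The chain of compound 3 is thus shorter than that of compound 1 but longer than that of compound 2, and since compound 2 sits higher than compound 1, a moderate rise in the number, beyond the scatter, is expected for the step of a 2.0-fold higher number from compound 1 to compound 3 (0.30 log units; within the scatter). For compound 3 the expected value is 10 uM, with a likely range from 4 uM to 25 uM.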

Compound 3, minimum effective concentration: 0.5 uM
Compound 3: the middle estimate sits 20-fold (1.30 log units) above what was measured, and the stated range ends above it.
By their numbers in this assay, from the lowest: compound 3; then compound 1; then compound 2.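

In this assay, methyl in place of hept-1-en-1-yl on a saturated chain carbon, nine bonds along the chain from a saturated ring carbon, gives a 10-fold lower number from compound 1 to compound 3 (1.00 log units; beyond the scatter) and shows that the larger group at this position is not required for the effect. Butyl in place of hydrogen on a saturated chain carbon, six bonds along the chain from a saturated ring carbon, gives a 40-fold lower number from compound 2 to compound 3 (1.60 log units; beyond the scatter) so both steps into compound 3 lower the number, one by removing chain atoms and the other by adding them. No supporting data explain this reversal.

The step from compound 1 removes chain length and the double bond together, so the shares of each remain unresolved; a saturated chain of matching length would separate them. Chains slightly shorter or longer than that of compound 3, and a carboxylic acid in place of the methyl ester, remain open.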